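From Fluoro to Phenyl: Expected Response of Compound 3

The compounds below may be only part of what the source reports. "The series", "measured", "known", "first", "only" and "open" are said of these compounds alone.

In an in vitro functional assay on SH-EP1 cells for agonist activity at Neuronal acetylcholine receptor; alpha4/beta2 (Homo sapiens), read by FLIPR and calcium flux (a higher number here means a larger maximal response, a lower number a smaller maximal response), compound 2 `Fc1ccc(C2=CC3CNCC(C2)C3)cn1` gives 104%. Compound 1 `Clc1ccc(C2=CC3CNCC(C2)C3)cn1` gives 98% in this assay. The step of a number 6 percentage points higher from compound 1 to compound 2 (within the scatter) lies within the scatter, so compound 2 holds the higher of the two numbers without standing apart from compound 1. Compound 3 `C1=C(c2ccc(-c3ccccc3)nc2)CC2CNCC1C2` has not yet been measured in this assay; it differs from compound 2 by phenyl in place of fluoro on an aromatic carbon. Going by the values given here, the only measured step, a number 6 percentage points higher from compound 1 to compound 2 (within the scatter), concerns fluoro in place of chloro on an aromatic carbon and is within the scatter; no measured step covers phenyl entering at this place. The expectation therefore rests only on both measured compounds reaching close to the full reference response, and the uncertainty is wide. Compound 3 is expected to give 80% in this assay, estimated between 40% and 110%. The expected step of a number 24 percentage points lower from compound 2 to compound 3 (beyond the scatter) is therefore estimated as downward but uncertain.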

Compound 3, largest response reached (reported as percent of maximum), in percent of the reference or control that the assay uses: 19%
Compound 3: middle estimate off by 61 percentage points, on the high side, outside the stated range (below it).
By their numbers in this assay, from the lowest: compound 3; then compounds 1 and 2 (each within the scatter of the next).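

In this assay, the aromatic carbon next to the ring nitrogen turns out not to accept every change equally: swapping chloro for fluoro left the response within the scatter, while phenyl in place of fluoro gives a number 85 percentage points lower from compound 2 to compound 3 (beyond the scatter) in a single change. Measured against chloro, the picture is the same, with a number 79 percentage points lower from compound 1 to compound 3 (beyond the scatter), so the large fall appears whichever of the two halogens serves as the starting point. Nothing measured here bears on why the response falls at this position.

On these data alone, it remains open where the fall begins between a single halogen atom and a whole phenyl ring, for instance with a methyl or a methoxy group on this carbon. As far as these compounds go, it also remains open whether the loss belongs to phenyl alone or extends to other rings, such as thienyl or pyridyl.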